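The source may hold more compounds than are shown below. What is called first, only, known or untested is meant among the compounds shown, and "the series" means these compounds.

In a functional assay on A-431 cells (Homo sapiens) for cytotoxicity, read by MTT assay, with a stated time of 48 h (a lower number here means a stronger inhibitor, a higher number a weaker inhibitor), compound 1 `COc1cc(-c2ocnc2-c2cc(Br)c(OC)c(OC)c2)ccc1SC` gives 410 nM, compound 2 `COc1cc(-c2ocnc2-c2cc(OC)c(OC)c(OC)c2)ccc1SC` gives 430 nM and compound 3 `COc1ccc(-c2c(-c3cc(OC)c(SC)c(OC)c3)ncn2C)cc1O` gives 430 nM. These three values lie within the scatter of each other, so compound 1 cannot be separated from the other two on these numbers.

Compound 4 `COc1ccc(-c2ocnc2-c2cc(Br)c(OC)c(OC)c2)cc1OC` comes from compound 1 by a single exchange, methoxy in place of methylsulfanyl on an aromatic carbon. Going by the values given here, no measured step covers this exchange, since all three measured compounds carry the methylsulfanyl group. Among the compounds with values here, the only measured step between close neighbours is a 1.0-fold higher number from compound 1 to compound 2 (0.02 log units; within the scatter), which puts methoxy in place of bromo on an aromatic carbon at another place in the molecule. It bears on the question only indirectly, showing one exchange on compound 1 that leaves this assay within the scatter.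

Going by these compounds, a step beyond the scatter is therefore not expected, though there is a slight lean towards a higher number and the uncertainty is wide because the exchange itself is untested. The estimate corresponds to an expected 1.5-fold higher number from compound 1 to compound 4 (0.17 log units; within the scatter). For compound 4 the estimated value is 600 nM, with an expected range from 150 nM to 2500 nM.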

Compound 4, half-maximal inhibitory concentration: 12300 nM
Beside the measured number, compound 4's estimate is 21-fold (1.31 log units) below it; measured number above the stated range.
By their numbers in this assay, from the lowest: compounds 1, 2 and 3 (each within the scatter of the next); then compound 4.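

In this assay, putting methoxy in place of methylsulfanyl on the aromatic carbon ortho to a methoxy group and para to a large group gives a 30-fold higher number from compound 1 to compound 4 (1.48 log units; beyond the scatter). Going by these compounds alone, the only earlier step, methoxy in place of bromo at another place in the molecule, gave a 1.0-fold higher number from compound 1 to compound 2 (0.02 log units; within the scatter), so this is the first sign that one exchange on the core of compound 1 can move the number well beyond the scatter, and it marks the methylsulfanyl position as sensitive to change. The leaving and entering groups have the same counts of heavy atoms, hydrogen-bond donors and acceptors, and differ in that one holds sulfur and the other oxygen, but no measurement here accounts for the size of the step.

The compounds shown leave open how other groups would fare at this position, such as ethylsulfanyl, a longer alkylsulfanyl chain, chloro or an amine. They also leave open whether the same exchange on compound 2 would produce a step of similar size.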